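From Methoxy to Propoxy on the Shared Core

This account rests on a few compounds, and the source may have more. Where it says the series, first, only, none or still open, it means among the compounds named here.

compound 1 `CCCCc1nc2cccc(C(=O)O)c2n1Cc1ccc(-c2ccccc2-c2noc(O)n2)cc1`: 68%
compound 2 `COc1nc2cccc(C(=O)O)c2n1Cc1ccc(-c2ccccc2-c2noc(O)n2)cc1`: 90%

In a functional assay on the whole organism for inhibition, with Rattus norvegicus as the target, with a stated time of 3 h, at a dose of 1 mg/kg by the oral route (on this read-out lower numbers stand for less inhibition and higher numbers for more inhibition at the one dose given (going by the name of the read-out)), compound 2 gives 90%, the higher of the two numbers measured, and compound 1 gives 68%. Compound 3 `CCCOc1nc2cccc(C(=O)O)c2n1Cc1ccc(-c2ccccc2-c2noc(O)n2)cc1` differs from compound 2 by ethyl in place of hydrogen on a saturated chain carbon bound to an oxygen on an aromatic ring, which reads, one bond further out, as methoxy to propoxy. Within the data shown here, the only measured step, a number 22 percentage points higher from compound 1 to compound 2 (beyond the scatter), shows that a shorter group on that aromatic carbon went with more inhibition in this assay. Compound 3 lengthens the group again, so a modest decrease is expected, a number 12 percentage points lower from compound 2 to compound 3 (beyond the scatter). Compound 3 is therefore estimated at 78%, between 60% and 92%.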

Compound 3, a percentage reported as inhibition, in the whole organism at one dose (the size of the read-out at that dose, not a potency): 100%
Beside the measured number, compound 3's estimate is 22 percentage points below it; measured number above the stated range.
By their numbers in this assay, from the lowest: compound 1; then compounds 2 and 3 (each within the scatter of the next).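

In this assay, methoxy to propoxy gives a number 10 percentage points higher from compound 2 to compound 3 (within the scatter), so the added ethyl does not separate these two compounds, and a shorter group on this aromatic carbon does not by itself go with more inhibition. Propoxy in place of butyl gives a number 32 percentage points higher from compound 1 to compound 3 (beyond the scatter), so both groups joined through oxygen stand clear of butyl in this set. From the compounds shown here alone, whether butoxy or an amine on that aromatic carbon would follow the same picture remains open. Nothing at hand bears on what lies behind these numbers.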